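A few compounds are considered here, and "the series" means these few. Any claim that something is new, unique, unknown or untested is made for them only; others in the source may bear on it.

Working notes on the series. Among the compounds with values here, in an ADME assay on MT4 cells (Homo sapiens) for cytotoxicity, read by MTT assay, with a stated time of 4 days (a lower number here means that less compound is tolerated, a higher number that more compound is tolerated), compound 2 `Cc1cc(-c2ccccc2Cl)cc(C)c1Nc1ccnc(Nc2ccc(C#N)cc2)n1` gives 3990 nM; the only other number so far belongs to compound 1 `Cc1cc(-c2ccccc2C(F)(F)F)cc(C)c1Nc1ccnc(Nc2ccc(C#N)cc2)n1`, which gives 4210 nM, within the scatter of compound 2. Within the data shown here, the single measured step, a 1.1-fold lower number from compound 1 to compound 2 (0.02 log units; within the scatter), likewise lies within the scatter. Compound 3 `Cc1ccc(-c2cc(C)c(Nc3ccnc(Nc4ccc(C#N)cc4)n3)c(C)c2)cc1` is not yet measured and differs from compound 2 by 4-methylphenyl in place of 2-chlorophenyl on an aromatic carbon. Among the measured compounds shown here, only the step from compound 1 to compound 2 bears on this change, and it was within the scatter, so in this assay no step beyond the scatter is expected. For compound 3 the estimate is 4000 nM, ranging from 2000 nM to 8000 nM. This corresponds to an expected 1.0-fold higher number from compound 2 to compound 3 (0.00 log units; within the scatter).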

Compound 3, half-maximal cytotoxic concentration: 5570 nM
Estimate against measurement, compound 3: 1.4-fold (0.14 log units) below; the measured number falls inside the stated range.
By their numbers in this assay, from the lowest: compounds 2, 1 and 3 (each within the scatter of the next).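

In this assay, moving from a halogen-bearing 2-substituted phenyl to 4-methylphenyl, with only carbon in the group, still gives no step beyond the scatter, either against the chloro compound (a 1.4-fold higher number from compound 2 to compound 3 (0.14 log units; within the scatter)) or against the trifluoromethyl compound (a 1.3-fold higher number from compound 1 to compound 3 (0.12 log units; within the scatter)). All three aryl groups at this aromatic carbon therefore stand within the scatter of one another, now across two ring placements of the substituent. No measured evidence accounts for this. From the compounds shown here alone, whether an amine or a carboxylic acid on this phenyl would give a step beyond the scatter stays open. So does the effect of a longer chain in place of the methyl of 4-methylphenyl.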